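The source may hold more compounds than are shown below. What is called first, only, known or untested is meant among the compounds shown, and "the series" means these compounds.

Compound 1 `COc1ccc2oc(C(c3ccccc3)c3c[nH]c4ccccc34)cc2c1` gives in a functional assay on SiHa cells (Homo sapiens) for cytotoxicity (on this read-out higher numbers stand for weaker inhibition and lower numbers for stronger inhibition), a value that is only a limit of the assay, > 100000 nM. Compound 2 `COc1ccc2oc(C(c3ccccc3)c3c(C)[nH]c4ccccc34)cc2c1` likewise reaches only the limit > 100000 nM. Compound 3 `CC(C)(C)c1cc(C(C)(C)C)c2oc(C(c3ccc(Cl)cc3)c3c[nH]c4ccccc34)cc2c1` gives a number, 49800 nM.

Compound 4 `Cc1[nH]c2ccccc2c1C(c1ccc(Cl)cc1)c1cc2cc(C(C)(C)C)cc(C(C)(C)C)c2o1` is not yet measured. It differs from compound 3 by methyl in place of hydrogen on an aromatic carbon. The same change is found between the measured compounds 1 and 2: methyl in place of hydrogen on an aromatic carbon. The size of that step, a step that the two limits leave unreadable from compound 1 to compound 2, cannot be read, due to the limit of > 100000 nM in this assay, at which 2 of the 3 values shown sit. The difference between the cores of compound 1 and compound 3 is not broken down here.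

Compound 3 gives 49800 nM, and with the matching step unreadable, compound 4 is expected to give 50000 nM, in the range 20000 nM to 100000 nM. The expected step is a 1.0-fold higher number from compound 3 to compound 4 (0.00 log units; within the scatter), essentially no change.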

Compound 4, half-maximal inhibitory concentration: 35900 nM
The estimate for compound 4 lay 1.4-fold (0.14 log units) above the measured number; low and high end bracket the measured number.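

In this assay, methyl in place of hydrogen on the core of compound 3 gives a 1.4-fold lower number from compound 3 to compound 4 (0.14 log units; within the scatter), so on this core the two compounds cannot be told apart. This is one readable pair, and it does not show whether the change behaves the same way on another core. The matching step on the core of compound 1 cannot be read, because compound 1 and compound 2 both stand at a limit and not at a number: the limit of > 100000 nM in this assay, at which 2 of the 4 values shown sit.

The compounds shown leave open whether a longer chain such as ethyl, an amine or a carboxylic acid at this place would give a step beyond the scatter. They also leave open which of the differences between the core of compound 1 and the core of compound 3 matters for this read-out.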